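The compounds below may be only part of what the source reports. "The series", "measured", "known", "first", "only" and "open" are said of these compounds alone.

Compound 1 `CCOC(=O)c1c(-c2ccccc2)oc2ccc(OCCCN3C(=O)/C(=N\OC)c4ccccc43)cc12` gives 64 ug/mL in an ADME assay on Vero cells (Chlorocebus sabaeus) for cytotoxicity, read by MTT assay, with a stated time of 72 h; a lower number here means that less compound is tolerated, a higher number that more compound is tolerated. Compound 2 `CCOC(=O)c1c(-c2ccc(OC)cc2)oc2ccc(OCCCN3C(=O)/C(=N\OC)c4ccccc43)cc12` gives 128 ug/mL in this assay. Compound 3 `CCOC(=O)c1c(-c2ccccc2)oc2ccc(OCCCCN3C(=O)/C(=N\OC)c4cc(F)ccc43)cc12` gives 64 ug/mL in this assay.

Going from compound 1 to compound 2, the change is methoxy in place of hydrogen on an aromatic carbon. It brought a 2.0-fold higher number from compound 1 to compound 2 (0.30 log units; within the scatter). Compound 4 `CCOC(=O)c1c(-c2ccc(OC)cc2)oc2ccc(OCCCCN3C(=O)/C(=N\OC)c4cc(F)ccc43)cc12` has not been measured; it differs from compound 3 by methoxy in place of hydrogen on an aromatic carbon, the same change at the same place. How the core of compound 3 differs from that of compound 1 is not broken down here; their values in this assay show no change at the digits printed.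

Compound 4 is expected to give about 100 ug/mL, because the same change earlier gave a 2.0-fold higher number from compound 1 to compound 2 (0.30 log units; within the scatter). Compound 4 is estimated to lie between 50 ug/mL and 200 ug/mL. Compound 4 is expected to show a 1.6-fold higher number from compound 3 to compound 4 (0.19 log units; within the scatter), a step of the kind seen before, which stays within the scatter.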

Compound 4, half-maximal cytotoxic concentration: 32 ug/mL
Compound 4: middle estimate off by 3.1-fold (0.49 log units), on the high side; the measured number lies below the stated range.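

In this assay, the methoxy change did not behave the same way on both cores, giving a 2.0-fold lower number from compound 3 to compound 4 (0.30 log units; within the scatter). Set beside the earlier step, the two results point in opposite directions: the same change on two cores in this assay, a 2.0-fold higher number (0.30 log units; within the scatter) from compound 1 to compound 2 and a 2.0-fold lower number (0.30 log units; within the scatter) from compound 3 to compound 4, 4.0-fold (0.60 log units) apart, beyond the scatter of two such steps. This shows that the step seen on the core of compound 1 cannot simply be carried over to the core of compound 3, but each step alone stays within the scatter, and the result does not show which feature of the two cores is responsible.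

The compounds shown leave open which of the differences between the two cores matters. Also open, on these data alone, is how an amine or a hydroxyl in place of the methoxy would behave on either core.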